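Replacing a trifluorophenethyl ether with an aryl-oxolane ether

The source may hold more compounds than are shown below. What is called first, only, known or untested is meant among the compounds shown, and "the series" means these compounds.

Measured compounds:
compound 1 `Cc1cc(CCOc2ccc(-c3c(C)nc(C)c([C@H](OC(C)(C)C)C(=O)O)c3N3CCC(C)(C)CC3)cc2)ccc1F`: > 2 h
compound 2 `Cc1nc(C)c([C@H](OC(C)(C)C)C(=O)O)c(N2CCC(C)(C)CC2)c1-c1ccc(OCCc2cc(F)c(F)cc2F)cc1`: > 2 h

Compound 1 and compound 2 share one core and differ only in the aryl group at the end of the ether chain. In an ADME assay on microsomes from liver (Rattus norvegicus) for metabolic stability, read by LC-MS, tested at 0.5 uM (a higher number here means that the compound lasts longer, a lower number that the compound disappears faster), compound 1 gives > 2 h, which is a limit of the assay and not a number. In this assay compound 2 gives > 2 h, again a limit. The step that the two limits leave unreadable from compound 1 to compound 2 is therefore unreadable. Compound 2 thus stands at the limit of > 2 h in this assay, at which 2 of the 2 values shown sit, with no number of its own.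

Compound 3 `Cc1nc(C)c([C@H](OC(C)(C)C)C(=O)O)c(N2CCC(C)(C)CC2)c1-c1ccc(OC2COCC2c2ccc(F)cc2)cc1` differs from compound 2 by 4-(4-fluorophenyl)oxolan-3-yl in place of 2-(2,4,5-trifluorophenyl)ethyl on an oxygen on an aromatic ring. Among the measured compounds shown here, only one measured step exists, and it is unreadable, so no measured step sizes this change. Given that every shown value sits at the limit of > 2 h in this assay, at which 2 of the 2 values shown sit, compound 3 is expected to give 2 h, with a range from 0.8 h to 4 h. The expected step of a number no higher from compound 2 to compound 3 (the limit leaves the size open) is estimated to stay within the usual scatter, with a fair chance that only a limit is reported.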

Compound 3, half-life: > 2 h
Compound 3: only a limit was reported; the forecaster's own chance of this, stated with the estimate: 55%; the middle value lies on the limit itself.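

In this assay compound 3 gives > 2 h, again a limit of the assay and not a number, so its steps from compound 1 and compound 2 cannot be read. The compounds shown leave open whether 4-(4-fluorophenyl)oxolan-3-yl in place of 2-(2,4,5-trifluorophenyl)ethyl changes the half-life at all.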